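A Ring Swap on the Amide-Type Ring Nitrogen

A few compounds are considered here, and "the series" means these few. Any claim that something is new, unique, unknown or untested is made for them only; others in the source may bear on it.

Three measured compounds share a five-membered non-aromatic ring with a nitrogen and a sulfur and differ mainly in the group on that ring nitrogen. Compound 1 `COc1ccccc1N1C(=O)CSC1c1cc(C(=O)NCCCCc2ccccc2)cc(C2CC2)c1` gives 23.5 nM in a functional assay on HOS-TE85 cells (Homo sapiens) for inhibition, read by CCK-8 assay, with a stated time of 72 h; a higher number here means a weaker inhibitor, a lower number a stronger inhibitor. Compound 2 `O=C(NCCCCn1cccn1)c1cccc(C2SCC(=O)N2c2cc(Br)ccn2)c1` gives 105 nM in this assay. For compound 3 `CC(C)(C)c1conc1N1C(=O)CSC1c1cccc(C(=O)NCCCCc2ccccc2)c1` the result in this assay is a limit rather than a number, > 1000 nM, and compound 3 therefore stands at the edge of what was measured (the limit of > 1000 nM in this assay, at which 1 of the 3 values shown sits).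

Compound 4 `COc1ccc(N2C(=O)CSC2c2cccc(C(=O)NCCCCc3ccccc3)c2)c(OC)c1` has not been measured. Compared with compound 3, the change is a group of 10 heavy atoms (8 carbon, 2 oxygen; one six-membered aromatic ring of carbon only) in place of a group of 9 heavy atoms (7 carbon, 1 nitrogen, 1 oxygen; one five-membered aromatic ring with 2 hetero atoms), on an amide-type nitrogen in a ring. Compound 1 also carries a methoxy-bearing six-membered aromatic ring of carbon only on that nitrogen and reaches 23.5 nM, though compound 1 differs from compound 4 in more than one place. Compound 4 is estimated to give 120 nM in this assay, within a range of 30 nM to 500 nM. The expected step of an at least 8.3-fold lower number from compound 3 to compound 4 (0.92 log units; beyond the scatter) is toward stronger inhibition and beyond the usual scatter.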

Compound 4, half-maximal inhibitory concentration: 90.4 nM
For compound 4 the middle estimate is 1.3-fold (0.12 log units) above the measured one, within the range that was stated.
By their numbers in this assay, from the lowest: compound 1; then compounds 4 and 2 (each within the scatter of the next). At a limit, above all of these: compound 3.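

Going by these compounds alone, compounds 3 and 4 give the first comparison in which only the group on the amide-type ring nitrogen changes. In this assay, putting 2,4-dimethoxyphenyl in place of the five-membered aromatic ring with 2 hetero atoms gives an at least 11-fold lower number from compound 3 to compound 4 (1.04 log units; beyond the scatter) and so a large move toward stronger inhibition, which shows that this position alone can shift the number well beyond the scatter. The value of compound 3 is a limit and not a number, so the step has a known minimum but no known full size: the limit of > 1000 nM in this assay, at which 1 of the 4 values shown sits.

The compounds shown leave open whether the six-membered carbon ring or its two methoxy groups matter more, which a plain phenyl ring would help to separate. They also do not show how a carboxylic acid or an amine on that ring would behave.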